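The source may report more compounds than this note shows. Statements on the series, on what has been measured and on what is new or still open speak of the compounds shown alone.

Compound 2 `Oc1ccc(O)c(-c2cc(-c3ccccc3)nn2-c2ccccc2)c1` carries hydroxyl groups on one aryl ring of the shared core; in a functional assay on cells (Leukemia cell, Homo sapiens) for cytotoxicity, read by sulforhodamine B assay, with a stated time of 48 h (on this read-out lower numbers stand for stronger inhibition of growth and higher numbers for weaker inhibition of growth), compound 2 gives 35700 nM, the highest number among the three measured compounds. Compound 3 `Oc1ccc(O)c(-c2cc(-c3ccc(Cl)cc3)nn2-c2ccccc2)c1` differs from it by a chloro in place of hydrogen on an aromatic carbon; in this assay compound 3 gives 3430 nM, and the step is a 10-fold lower number from compound 2 to compound 3 (1.02 log units; beyond the scatter). Compound 1 `COc1ccc(OC)c(-c2cc(-c3ccccc3)nn2-c2ccc(S(N)(=O)=O)cc2)c1` carries a sulfamoyl group together with methoxy groups in place of the hydroxyls; in this assay compound 1 gives 6940 nM. Compound 4 `NS(=O)(=O)c1ccc(-n2nc(-c3ccccc3)cc2-c2cc(O)ccc2O)cc1` has not been measured. Its change from compound 2 is sulfamoyl in place of hydrogen on an aromatic carbon. For the measured compounds named here, no measured step covers this change on its own. The pair compound 1 and compound 2 shows the lower number for the sulfamoyl-bearing compound 1, but the methoxy groups also differ between them, so the comparison is indirect. The chloro step from compound 2 to compound 3 concerns a different group and does not transfer. A moderate lowering is expected; the step from compound 2 to compound 4 is estimated at a 3.0-fold lower number from compound 2 to compound 4 (0.47 log units; beyond the scatter). For compound 4 the expected value in this assay is 12000 nM, with a range from 4000 nM to 36000 nM.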

Compound 4, concentration for 50% growth inhibition: 49600 nM
Estimate against measurement, compound 4: 4.1-fold (0.62 log units) below; the measured number lies above the stated range.
By their numbers in this assay, from the lowest: compound 3; then compound 1; then compounds 2 and 4 (each within the scatter of the next).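

In this assay, sulfamoyl in place of hydrogen on an aromatic carbon, para to a large group, gives a 1.4-fold higher number from compound 2 to compound 4 (0.14 log units; within the scatter), so with the hydroxyl groups in place, compound 2 and compound 4 cannot be told apart and this position shows no measurable response to the sulfamoyl group. With sulfamoyl held constant, 2,5-dihydroxyphenyl in place of 2,5-dimethoxyphenyl gives a 7.1-fold higher number from compound 1 to compound 4 (0.85 log units; beyond the scatter), which means that among these compounds the lower number of compound 1 goes with the methoxy groups and not with the sulfamoyl group, a separation that the indirect pair of compound 1 and compound 2 could not make. No data on the reason for either step are at hand.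

The compounds shown leave open whether a carboxylic acid or an amine at the same place, on the aromatic carbon para to a large group, would also leave the number unchanged within the scatter. They also leave open whether the chloro change, seen as a 10-fold lower number from compound 2 to compound 3 (1.02 log units; beyond the scatter), would carry over to a compound that also bears sulfamoyl.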